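The source may report more compounds than this note shows. Statements on the series, on what has been measured and on what is new or still open speak of the compounds shown alone.

Measured compounds:
- compound 1, `COc1ccc([C@@H]2CC(=O)c3c(O)cc(OCc4cn(Cc5ccccc5Cl)nn4)cc3O2)cc1O`: 6140 nM
- compound 2, `COc1ccc([C@@H]2CC(=O)c3c(O)cc(OCc4cn(Cc5cccc(C(F)(F)F)c5)nn4)cc3O2)cc1O`: 19900 nM
- compound 3, `COc1ccc([C@@H]2CC(=O)c3c(O)cc(OCc4cn(C5CCC5)nn4)cc3O2)cc1O`: 15300 nM

In a functional assay on RAW264.7 cells (Mus musculus) for inhibition, read by Griess assay, with stated times of 2 h and 24 h (on this read-out lower numbers stand for stronger inhibition and higher numbers for weaker inhibition), compound 1 gives the lowest of the three numbers. Its nearest neighbour is compound 3, reached by a 2.5-fold higher number from compound 1 to compound 3 (0.40 log units; beyond the scatter), and its furthest is compound 2, reached by a 3.2-fold higher number from compound 1 to compound 2 (0.51 log units; beyond the scatter). Between compound 2 and compound 3 the step is a 1.3-fold lower number from compound 2 to compound 3 (0.11 log units; within the scatter).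

The unmeasured compound 4, `CCCCn1cc(COc2cc(O)c3c(c2)O[C@H](c2ccc(OC)c(O)c2)CC3=O)nn1`, differs from compound 1 in one place: propyl in place of 2-chlorophenyl on a saturated chain carbon bound to an aromatic nitrogen.

For the measured compounds named here, two measured steps bear on this change, since both start from compound 1 and both replace the 2-chlorobenzyl on the aromatic nitrogen. Compound 3 carries a cyclobutyl there, and the step of a 2.5-fold higher number from compound 1 to compound 3 (0.40 log units; beyond the scatter) goes to a higher number. Compound 2 carries a 3-(trifluoromethyl)benzyl there, and the step of a 3.2-fold higher number from compound 1 to compound 2 (0.51 log units; beyond the scatter) also goes to a higher number. Every replacement of the 2-chlorobenzyl seen so far has given a weaker result in this assay, and the butyl of compound 4 is, like the cyclobutyl of compound 3, a small group without a ring of aromatic carbon.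

Compound 4 is therefore expected to give a higher number than compound 1, with an estimated step of a 2.4-fold higher number from compound 1 to compound 4 (0.39 log units; beyond the scatter). In this assay compound 4 is estimated at 15000 nM, in a range from 6000 nM to 40000 nM.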

Compound 4, half-maximal inhibitory concentration: 13900 nM
Beside the measured number, compound 4's estimate is 1.1-fold (0.03 log units) above it; low and high end bracket the measured number.
By their numbers in this assay, from the lowest: compound 1; then compounds 4, 3 and 2 (each within the scatter of the next).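

In this assay, the butyl, which has no ring, also falls short of the 2-chlorobenzyl, with a 2.3-fold higher number from compound 1 to compound 4 (0.35 log units; beyond the scatter), so the loss on leaving the 2-chlorobenzyl is now seen with a straight chain as well as with a cyclobutyl and a substituted benzyl. The butyl cannot be separated from the cyclobutyl, with a 1.1-fold lower number from compound 3 to compound 4 (0.04 log units; within the scatter), or from the 3-(trifluoromethyl)benzyl, with a 1.4-fold lower number from compound 2 to compound 4 (0.16 log units; within the scatter). On this position, then, the four compounds form one group of three with compound 1 apart from it, and an aromatic ring alone does not set compound 1 apart, as compound 2 also carries one and stays level with the two compounds that have none. Nothing measured here explains this difference.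

The compounds shown leave open whether the chlorine itself matters, which an unsubstituted benzyl on the same nitrogen would test against compound 1. They also leave open whether a longer chain, or a butyl chain ending in an amine, would stay with compound 4 or move away from it.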